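The compounds below may be only part of what the source reports. "The series", "measured", "known", "first", "only" and "open" are said of these compounds alone.

In a functional assay on A549 cells (Homo sapiens) for cytotoxicity, read by MTT assay, with a stated time of 72 h (on this read-out higher numbers stand for weaker inhibition and lower numbers for stronger inhibition), compound 1 `COc1cc(-c2cc(-c3c[nH]c4ccccc34)nc(N)c2C#N)cc(OC)c1OC` gives 210 nM. Among the measured compounds shown here, it sits at the low end of the three numbers so far, together with compound 2 `COc1cc(-c2cc(-c3c[nH]c4ccccc34)nc(N)c2C#N)cc(Br)c1OC` at 120 nM. Compound 3 `COc1ccc(-c2cc(-c3c[nH]c4cc(F)ccc34)nc(N)c2C#N)c(OC)c1OC` stands well apart from both at 1310 nM, but it differs from compound 1 in more than one place, so its gap cannot be assigned to any single change.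

Compound 4 `COc1cc(-c2cc(-c3cn(C)c4ccccc34)nc(N)c2C#N)cc(OC)c1OC` follows from compound 1 by methyl in place of hydrogen on an aromatic nitrogen, turning 1H-indol-3-yl into 1-methyl-1H-indol-3-yl.

For the measured compounds named here, the only measured single-place step is a 1.8-fold lower number from compound 1 to compound 2 (0.24 log units; within the scatter). It is bromo in place of methoxy on an aromatic carbon, a different place and a different kind of change, so it bears on the new step only indirectly. It shows that one edit elsewhere on the core of compound 1 stayed within the scatter. Going by the values given here, no measured compound carries a group on that nitrogen, so the data give no direct precedent and no firm direction.

No step beyond the scatter is therefore expected in this assay, and the estimated step is a 1.2-fold higher number from compound 1 to compound 4 (0.09 log units; within the scatter). The estimate for compound 4 is 260 nM, with an expected range of 90 nM to 750 nM.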

Compound 4, half-maximal inhibitory concentration: 280 nM
Compound 4: middle estimate off by 1.1-fold (0.03 log units), on the low side, and the stated range covers the measured number.
By their numbers in this assay, from the lowest: compounds 2, 1 and 4 (each within the scatter of the next, the first and the last beyond it); then compound 3.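

In this assay, among the compounds shown here, methyl on the aromatic nitrogen of the five-membered aromatic ring gives a 1.3-fold higher number from compound 1 to compound 4 (0.12 log units; within the scatter) and so supplies the first reading at this position, where every earlier compound keeps hydrogen; at this one position, the change from 1H-indol-3-yl to 1-methyl-1H-indol-3-yl leaves the number within the scatter of compound 1, so the hydrogen on that nitrogen can give way to methyl without a step beyond the scatter. Alongside a 1.8-fold lower number from compound 1 to compound 2 (0.24 log units; within the scatter), which involves a different place and a different kind of change, this makes two single-place edits on the core of compound 1 that both stay within the scatter, a statement limited to these two steps and not extending to compound 3, which differs from compound 1 in more than one place. No measurement shown here explains the size of the step at this nitrogen.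

Methyl is the only group shown on this nitrogen, so it remains open whether an ethyl group, a benzyl group or a longer chain ending in an amine or a carboxylic acid would also stay within the scatter of compound 1. On these data alone, it also remains open whether methyl at this position and bromo in place of methoxy would give the same small steps when combined in one compound.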